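Methylsulfanyl for Methyl: a Small Step in a Benzamide Series

The source may hold more compounds than are shown below. What is called first, only, known or untested is meant among the compounds shown, and "the series" means these compounds.

Measured compounds:
compound 1 `COc1ccc(C(=O)Nc2ccccc2Cl)cc1OC1CCCC1` with 190 nM
compound 2 `COc1ccc(C(=O)Nc2ccccc2C)cc1OC1CCCC1` with 300 nM
compound 3 `COc1ccc(C(=O)Nc2c(F)cccc2F)cc1OC1CCCC1` with 70 nM

All three compounds were tested in an assay on isolated protein for inhibition of phosphodiesterase 4A (Sus scrofa); on this read-out lower numbers stand for stronger inhibition and higher numbers for weaker inhibition. Compound 2 gives the highest number of the three. Its nearest neighbour is compound 1, reached by a 1.6-fold higher number from compound 1 to compound 2 (0.20 log units; within the scatter), a shift that does not stand out from the noise of the assay. The furthest is compound 3, reached by a 4.3-fold lower number from compound 2 to compound 3 (0.63 log units; beyond the scatter), a clearer change.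

Compound 4 `COc1ccc(C(=O)Nc2ccccc2SC)cc1OC1CCCC1` has not been measured. It differs from compound 2 in one place: methylsulfanyl in place of methyl on an aromatic carbon. Of the measured steps, only the exchange from compound 1 to compound 2 touches the same position with a small group, and that step stayed within the scatter; the exchange to compound 3 changes two positions at once and so speaks less directly to this case. Among the compounds with values here, no measured step involves methylsulfanyl. The expectation is therefore a small step, likely within the scatter, with a slight lean toward a lower number given that compound 2 already sits at the top of the range. The estimate for compound 4 in this assay is 230 nM, with a range from 90 nM to 600 nM, which corresponds to an expected step of a 1.3-fold lower number from compound 2 to compound 4 (0.12 log units; within the scatter).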

Compound 4, half-maximal inhibitory concentration: 1200 nM
Compound 4: the middle estimate sits 5.2-fold (0.72 log units) below what was measured; the whole stated range lies below it.
By their numbers in this assay, from the lowest: compound 3; then compounds 1 and 2 (each within the scatter of the next); then compound 4.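

In this assay, chloro and methyl on this aromatic carbon had stayed within the scatter of each other, which could suggest that the position tolerates small changes, but methylsulfanyl shows that it does not tolerate every small group. Replacing methyl with methylsulfanyl raises the number (a 4.0-fold higher number from compound 2 to compound 4 (0.60 log units; beyond the scatter)), and replacing chloro with it does the same (a 6.3-fold higher number from compound 1 to compound 4 (0.80 log units; beyond the scatter)), so a change of only one extra heavy atom over methyl can move this read-out beyond the scatter, and the full span of the set widens to a large step (a 17-fold higher number from compound 3 to compound 4 (1.23 log units; beyond the scatter)). Nothing measured here bears on why methylsulfanyl gives this result.

The compounds shown leave open whether the higher number goes with the sulfur itself or simply with a two-atom group at this carbon, a question that an ethyl or a methoxy group in the same place would help to separate. Also open, on these data alone, is how a single fluoro at this carbon would compare, and whether a second group on the ring of compound 4 would bring the number down.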